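This account rests on a few compounds, and the source may have more. Where it says the series, first, only, none or still open, it means among the compounds named here.

In a functional assay on HeLa cells (Homo sapiens) for antiproliferative activity, read by MTT assay, with a stated time of 72 h (on this read-out higher numbers stand for weaker inhibition and lower numbers for stronger inhibition), compound 1 (`COc1cc(-c2nccn2C)cc(OC)c1OC`) gives > 100000 nM, which is a limit and not a number. Compound 2 (`CCn1ccnc1-c1cc(OC)c(OC)c(OC)c1`) gives > 100000 nM, also a limit. Among the measured compounds shown here, compound 3 (`COc1ccc(-n2ccnc2-c2cc(OC)c(OC)c(OC)c2)cc1[N+](=O)[O-]`) gives 2500 nM, the only true number so far. The rest of the data amount to the limit of > 100000 nM in this assay, at which 2 of the 3 values shown sit. For the measured compounds named here, the one measured step, a step that the two limits leave unreadable from compound 1 to compound 2, lies at another place and has no readable size to carry over. The next change leads to compound 4 (`COc1ccc(-n2ccnc2-c2cc(OC)c(OC)c(OC)c2)cc1`): hydrogen in place of nitro on an aromatic carbon. Going by the values given here, no measured step bears on this place, so no direction can be derived, and no shift beyond the scatter is expected in this assay. The expected change is a 1.3-fold lower number from compound 3 to compound 4 (0.10 log units; within the scatter). For compound 4 the estimated value is 2000 nM, with an expected range of 300 nM to 15000 nM.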

Compound 4, half-maximal inhibitory concentration: 1200 nM
Estimate against measurement, compound 4: 1.7-fold (0.22 log units) above; low and high end bracket the measured number.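

In this assay, the nitro group on this aromatic carbon, ortho to a methoxy group, is not required for activity, and replacing it with hydrogen brings a modest gain: a 2.1-fold lower number from compound 3 to compound 4 (0.32 log units; beyond the scatter). The 4-methoxyphenyl group on the aromatic nitrogen, in place of a small alkyl group, gives far larger steps: an at least 83-fold lower number from compound 2 to compound 4 (1.92 log units; beyond the scatter) and an at least 83-fold lower number from compound 1 to compound 4 (1.92 log units; beyond the scatter). Those two sizes rest on a limit, not a number: the limit of > 100000 nM in this assay, at which 2 of the 4 values shown sit.

On these data alone, whether an amine or a hydroxyl group on this aromatic carbon would keep or improve on compound 4 remains open. So does the effect of a benzyl group on the aromatic nitrogen.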